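Swapping Phenyl for a Chloro-Trifluoromethyl Ring

A few compounds are considered here, and "the series" means these few. Any claim that something is new, unique, unknown or untested is made for them only; others in the source may bear on it.

Compound 1 `O=C(Nc1ccc(Oc2ccnc3[nH]ccc23)cc1)c1nn(-c2ccc(Cl)c(C(F)(F)F)c2)ccc1=O`: 2190 nM
Compound 2 `Cn1ccc2c(Oc3ccc(NC(=O)c4nn(-c5ccccc5)ccc4=O)cc3)ccnc21`: 51700 nM

Among the measured compounds shown here, in a functional assay on A549 cells (Homo sapiens) for cytotoxicity, read by MTT assay, with a stated time of 72 h (on this read-out lower numbers stand for stronger inhibition and higher numbers for weaker inhibition), compound 2 gives 51700 nM, the highest of the two numbers measured so far; compound 1 gives 2190 nM, a far lower number, beyond the scatter. Compound 3 `Cn1ccc2c(Oc3ccc(NC(=O)c4nn(-c5ccc(Cl)c(C(F)(F)F)c5)ccc4=O)cc3)ccnc21` differs from compound 2 by 4-chloro-3-(trifluoromethyl)phenyl in place of phenyl on an aromatic nitrogen. For the measured compounds named here, no measured pair differs in this one place alone, so the size of the step is uncertain. A clear drop in the number is expected, because compound 1 carrying this same entering group gives 2190 nM. Compound 3 is therefore estimated at 4000 nM, within 1200 nM to 15000 nM. This expectation means a step of a 13-fold lower number from compound 2 to compound 3 (1.11 log units; beyond the scatter), beyond the scatter.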

Compound 3, half-maximal inhibitory concentration: 11400 nM
For compound 3 the middle estimate is 2.9-fold (0.45 log units) below the measured one, and the stated range covers the measured number.
By their numbers in this assay, from the lowest: compound 1; then compound 3; then compound 2.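

With the rest of the molecule held the same, the ring on the aromatic nitrogen can now be judged by itself: in this assay, 4-chloro-3-(trifluoromethyl)phenyl in place of phenyl gives a 4.5-fold lower number from compound 2 to compound 3 (0.66 log units; beyond the scatter), a modest gain in strength. A second change can also be read alone, as methyl in place of hydrogen on an aromatic nitrogen gives a 5.2-fold higher number from compound 1 to compound 3 (0.72 log units; beyond the scatter), a modest loss. Nothing available explains either step.

Still open, from the compounds shown here alone, is whether the chlorine or the trifluoromethyl alone accounts for the gain. Going by these compounds, whether a ring carrying an amine or a methoxy group would lower the number as well also remains unknown.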